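Trading a Bromophenyl for a Vinyl at the Sulfur Chain

The source may report more compounds than this note shows. Statements on the series, on what has been measured and on what is new or still open speak of the compounds shown alone.

Compound 3 `Cc1cc(Nc2cc(-c3ccccc3)[nH]n2)n2nc(SCc3ccc(Br)cc3)nc2n1` is one of three related compounds tested in a functional assay on MCF7 cells (Homo sapiens) for inhibition, read by MTT assay, with a stated time of 72 h; on this read-out lower numbers stand for stronger inhibition and higher numbers for weaker inhibition. Compound 3 gives 2720 nM, the lowest of the two numbers reported, and compound 1 `Cc1cc(Nc2cc(-c3ccccc3)[nH]n2)n2nc(SCc3ccccc3Br)nc2n1` stands nearest to it with 3020 nM, a gap that is within the scatter (a 1.1-fold lower number from compound 1 to compound 3 (0.05 log units; within the scatter)). Compound 2 `CCCSc1nc2nc(C)cc(Nc3cc(-c4ccccc4)[nH]n3)n2n1` gives only a limit of the assay, > 50000 nM, so no number is known for it (the limit of > 50000 nM in this assay, at which 1 of the 3 values shown sits).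

Compound 4 `C=CCSc1nc2nc(C)cc(Nc3cc(-c4ccccc4)[nH]n3)n2n1` differs from compound 3 in one place: vinyl in place of 4-bromophenyl on a saturated chain carbon bound to a sulfur. Among the measured compounds shown here, two measured steps bear on this change. Replacing a bromophenyl with ethyl at the same place produced an at least 16-fold higher number from compound 1 to compound 2 (1.21 log units; beyond the scatter), and the reverse replacement produced an at least 18-fold lower number from compound 2 to compound 3 (1.26 log units; beyond the scatter). Both steps are large and point the same way: a chain without a ring at this position gives a far higher number than a bromophenyl. Vinyl, like ethyl, is a chain without a ring, so a large step upward is expected here too, and the result may again be reported only as a limit. Compound 4 is therefore expected to reach about 40000 nM, within a range from 12000 nM to 150000 nM, which means an expected step of a 15-fold higher number from compound 3 to compound 4 (1.17 log units; beyond the scatter).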

Compound 4, half-maximal inhibitory concentration: > 50000 nM
Compound 4: only a limit was reported (the forecaster's own chance of this, stated with the estimate: 60%); at least 1.2-fold (0.09 log units) between middle value and limit.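

In this assay, vinyl in place of 4-bromophenyl gives an at least 18-fold higher number from compound 3 to compound 4 (1.26 log units; beyond the scatter), and vinyl in place of 2-bromophenyl gives an at least 16-fold higher number from compound 1 to compound 4 (1.21 log units; beyond the scatter). The large gap between the bromophenyl compounds and the compounds without a ring at this position therefore no longer rests on ethyl alone: it now holds for a second small group, one that carries a double bond outside aromatic rings. Compound 4, like compound 2, sits at a limit and has no exact number, so the step between them cannot be read and any difference between vinyl and ethyl stays hidden: the limit of > 50000 nM in this assay, at which 2 of the 4 values shown sit.

The compounds shown do not separate the effect of the ring from that of its bromine, which a plain benzyl group with no bromine could address, and a longer chain such as hexyl could test whether a chain without a ring can reach the range of the bromophenyl compounds. They also leave open what an amine or a carboxylic acid at the end of the chain would do to the number in this assay.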